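The source may hold more compounds than are shown below. What is called first, only, known or untested is meant among the compounds shown, and "the series" means these compounds.

Measured so far in a physicochemical assay for solubility, at pH 7.4; a higher number here means a more soluble compound, a lower number a less soluble compound:
- Compound 1 `Cc1cc(NC(=O)Nc2ccc(C(C)(C)C)cc2)c2ccccc2n1`: 6200 nM
- Compound 2 `CC(=O)c1ccc(NC(=O)Nc2cc(C)nc3ccccc23)cc1`: 3800 nM

Compound 2, at 3800 nM, lies within the usual scatter of compound 1, so these two numbers cannot be ranked. The next molecule is compound 3 `Cc1ccc(NC(=O)Nc2cc(C)nc3ccccc23)cc1`, which has not yet been measured. It differs from compound 2 in one place, with methyl in place of acetyl on an aromatic carbon, para to a large group (methyl in place of acetyl on an aromatic carbon).

Among the compounds with values here, only one measured step bears on this change. It is a 1.6-fold lower number from compound 1 to compound 2 (0.21 log units; within the scatter), in which acetyl replaces tert-butyl, also on an aromatic carbon para to a large group. Within the data shown here, that step stays within the scatter, but a single step is thin evidence, and no measured compound carries methyl at this carbon. On these data alone, a change beyond the scatter in this assay is therefore not expected, and the direction remains open. The expected step is a 1.2-fold higher number from compound 2 to compound 3 (0.07 log units; within the scatter). For compound 3 the estimated value is 4500 nM, with an expected range from 1800 nM to 11000 nM.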

Compound 3, solubility: 1300 nM
Estimate against measurement, compound 3: 3.5-fold (0.54 log units) above; measured number outside the range, below it.
By their numbers in this assay, from the lowest: compound 3; then compounds 2 and 1 (each within the scatter of the next).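

In this assay, this aromatic carbon, para to a large group, now proves sensitive to what it carries: methyl in place of acetyl gives a 2.9-fold lower number from compound 2 to compound 3 (0.47 log units; beyond the scatter). Within the data shown here, the only earlier step at this carbon, between tert-butyl and acetyl, could not be told from the scatter, so this is the first clear change seen here. Methyl in place of tert-butyl gives a 4.8-fold lower number from compound 1 to compound 3 (0.68 log units; beyond the scatter), so compound 3 stands apart from both compound 1 and compound 2, which themselves cannot be ranked, and methyl is the one group of these three that separates from the others.

No measurement among these compounds accounts for that separation, so the numbers show the size of the change but not its cause. On these data alone, it also remains open whether an amine, a methoxy group or a carboxylic acid at this carbon would fall with methyl or with acetyl and tert-butyl, and whether a longer chain would behave like any of them.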